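A few compounds are considered here, and "the series" means these few. Any claim that something is new, unique, unknown or untested is made for them only; others in the source may bear on it.

Measured compounds in an ADME assay on PBMC cells (Homo sapiens) for cytotoxicity, with a stated time of 5 days; on this read-out lower numbers stand for stronger inhibition and higher numbers for weaker inhibition:
- compound 1, `C=CCN(C)c1nc(N)nc2c1ncn2[C@H]1C[C@H](N=[N+]=[N-])[C@@H](CO)O1`: > 100000 nM
- compound 2, `CNc1nc(Cl)nc2c1ncn2[C@H]1C[C@H](N=[N+]=[N-])[C@@H](CO)O1`: > 100000 nM

In this assay compound 1 gives > 100000 nM, which is a limit of the assay and not a number. Compound 2 likewise gives only a limit in this assay, > 100000 nM. Both values sit at the same point, (the limit of > 100000 nM in this assay, at which 2 of the 2 values shown sit), so compound 1 cannot be placed above or below compound 2 on the numbers shown; all that is known is that neither reaches a measurable half-maximal inhibitory concentration in this assay.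

Compound 3, `[N-]=[N+]=N[C@H]1C[C@H](n2cnc3c(NC4CC4)nc(N)nc32)O[C@@H]1CO`, is not yet measured in this assay. It differs from compound 1 in one place: cyclopropylamino in place of allyl(methyl)amino on an aromatic carbon. Among the measured compounds shown here, no step between two measured compounds is available, so the size of this change cannot be read from the data.

Given that compound 1 sits at the limit, compound 3 is expected to sit at the limit as well. The step that the limit leaves unreadable from compound 1 to compound 3 is expected to be none beyond the scatter. Compound 3 is estimated at 150000 nM, in a range from 50000 nM to 500000 nM.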

Compound 3, half-maximal inhibitory concentration: > 100000 nM
Compound 3 ended at the assay's limit; the forecaster's own chance of this, stated with the estimate: 85%; the middle value is on the limit's open side.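

No step can be read between compound 1 and compound 3 in this assay, since both values are limits of the assay and not numbers: the limit of > 100000 nM in this assay, at which 3 of the 3 values shown sit.

The compounds shown leave open whether any group on the shared core gives a measurable value in this assay, and so how cyclopropylamino and allyl(methyl)amino compare.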